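A few compounds are considered here, and "the series" means these few. Any claim that something is new, unique, unknown or untested is made for them only; others in the source may bear on it.

Working notes on the series. In a functional assay on HeLa cells (Homo sapiens) for inhibition, read by CCK-8 assay, with a stated time of 72 h (on this read-out higher numbers stand for weaker inhibition and lower numbers for stronger inhibition), compound 1 (`O=C(/C=C/c1cccnc1)NCCCCCCc1cccc(S(=O)(=O)Nc2ccccc2)c1`) gives 30.4 nM and compound 2 (`Cc1ccc(NS(=O)(=O)c2cccc(CCCCCCNC(=O)/C=C/c3cccnc3)c2)cc1`) gives 38.8 nM, and a 1.3-fold higher number from compound 1 to compound 2 (0.11 log units; within the scatter) leaves these two together. Compound 3 (`O=C(/C=C/c1cccnc1)NCCCCCCc1cccc(S(=O)(=O)Nc2ccc(Cl)cc2)c1`) gives 170 nM, the highest number of the three and so the weakest inhibition so far.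

Compound 4 (`O=C(/C=C/c1cccnc1)NCCCCCCc1cccc(S(=O)(=O)Nc2ccc(F)cc2)c1`) departs from compound 3 at a single place: fluoro in place of chloro on an aromatic carbon. This is fluoro in place of chloro on an aromatic carbon, para to a large group.

Among the measured compounds shown here, no fluoro compound has been measured, so the evidence is indirect. Two steps introduce the chloro group: chloro in place of hydrogen gives a 5.6-fold higher number from compound 1 to compound 3 (0.75 log units; beyond the scatter), and chloro in place of methyl gives a 4.4-fold higher number from compound 2 to compound 3 (0.64 log units; beyond the scatter). Both are modest. Methyl in place of hydrogen, by contrast, gives a 1.3-fold higher number from compound 1 to compound 2 (0.11 log units; within the scatter). Among these three compounds, only the chloro compound stands apart, so losing the chloro group may recover part of that gap, though how much of it a fluoro group would recover is not known. The expected change is a 2.8-fold lower number from compound 3 to compound 4 (0.45 log units; beyond the scatter), a modest move towards stronger inhibition. For compound 4 the estimated value is 60 nM, with an expected range of 25 nM to 170 nM.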

Compound 4, half-maximal inhibitory concentration: 99.9 nM
Beside the measured number, compound 4's estimate is 1.7-fold (0.22 log units) below it; the measured number falls inside the stated range.
By their numbers in this assay, from the lowest: compounds 1 and 2 (each within the scatter of the next); then compounds 4 and 3 (each within the scatter of the next).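

On this aromatic carbon, para to a large group, fluoro in place of chloro gives a step that stays within the scatter in this assay (a 1.7-fold lower number from compound 3 to compound 4 (0.23 log units; within the scatter)), so the two groups cannot be told apart at this position. Compound 4 also stays apart from the compounds without a halogen, with fluoro in place of hydrogen (a 3.3-fold higher number from compound 1 to compound 4 (0.52 log units; beyond the scatter)) and fluoro in place of methyl (a 2.6-fold higher number from compound 2 to compound 4 (0.41 log units; beyond the scatter)) both giving steps beyond the scatter, which means the gap first seen with compound 3 is not confined to chloro, while compound 2, with its methyl group, goes against any reading that every group at this position opens such a gap. Nothing in hand accounts for fluoro and chloro sitting together here or for methyl sitting with hydrogen.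

The compounds shown leave open whether a methoxy, a trifluoromethyl or an amine on this carbon would sit with compounds 1 and 2 or with compounds 3 and 4. Also open, on these data alone, is whether fluoro or chloro on another carbon of the same ring would give steps of similar size.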